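The source may report more compounds than this note shows. Statements on the series, on what has been measured and on what is new or still open speak of the compounds shown alone.

Compound 2 `CCCCCCc1cn([C@@H]2O[C@@H]3COP(=O)(O)O[C@H]3[C@H]2O)c(=O)nc1N` carries a hexyl chain on the shared core. In a functional assay on L1210 cells (Mus musculus) for cytotoxicity (on this read-out lower numbers stand for stronger inhibition and higher numbers for weaker inhibition), compound 2 gives > 200 ug/mL, which is a limit of the assay rather than a measured number. The related compound 1 `Cc1cn([C@@H]2O[C@@H]3COP(=O)(O)O[C@H]3[C@H]2O)c(=O)nc1N` has a methyl in that place. In this assay compound 1 gives > 200 ug/mL, again only a limit. The step that the two limits leave unreadable from compound 1 to compound 2 cannot be read, since the limit of > 200 ug/mL in this assay, at which 2 of the 2 values shown sit, is where both values sit. Compound 3 `CCc1cn([C@@H]2O[C@@H]3COP(=O)(O)O[C@H]3[C@H]2O)c(=O)nc1N` differs from compound 2 by hydrogen in place of butyl on a saturated chain carbon, two bonds along the chain from an aromatic carbon. Going by the values given here, the only step that bears on this change, the one from methyl to hexyl, was unreadable, and compound 3 lies between those two chain lengths, so no direction can be expected beyond the scatter. Compound 3 is therefore expected to give 300 ug/mL in this assay, most likely again as a limit, within a range from 150 ug/mL to 1000 ug/mL, a step that the limit leaves unreadable from compound 2 to compound 3 that is expected to be none beyond the scatter.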

Compound 3, concentration for 50% inhibition: > 200 ug/mL
Compound 3: a limit, no number; the forecaster's own chance of this, stated with the estimate: 85%; the middle value lies beyond the limit too.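

No new step can be read among compound 1, compound 2 and compound 3, since all three stop at a limit of the assay rather than a number: the limit of > 200 ug/mL in this assay, at which 3 of the 3 values shown sit. The compounds shown leave open whether the methyl, ethyl and hexyl chains differ at all in this assay.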